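Removing one chain from a pyridinium-type salt

The source may report more compounds than this note shows. Statements on the series, on what has been measured and on what is new or still open speak of the compounds shown alone.

Measured in a functional assay on M12 cells (Homo sapiens) for antiproliferative activity, read by WST assay, with a stated time of 72 h; a lower number here means that less compound is needed, a higher number that more compound is needed for the effect:

Compound 1 `CCCCCCCC/C=C\c1c(C)c(/C=C\CCCCCCCC)c2[n+](c1C)CCC2` gives 3.3 uM
Compound 2 `CCCCCCCC/C=C/c1c(C)c(/C=C/CCCCCCCC)c2[n+](c1C)CCC2` gives 2.2 uM
Compound 3 `CCCCCCCC/C=C\c1c(C)c(/C=C/CCCCCCCC)c(C)[n+]2c1CCC2` gives 2.4 uM

Compound 2 cannot be separated from the other two compounds. The steps are a 1.5-fold lower number from compound 1 to compound 2 (0.18 log units; within the scatter) and a 1.1-fold higher number from compound 2 to compound 3 (0.04 log units; within the scatter), and also a 1.4-fold lower number from compound 1 to compound 3 (0.14 log units; within the scatter). Compound 4 `CCCCCCCC/C=C/c1c(C)cc(C)[n+]2c1CCC2` differs from compound 2 as follows: a hydrogen atom in place of a group of 10 heavy atoms (10 carbon; no ring), on an aromatic carbon. A hydrogen atom stands in place of that group, on an aromatic carbon. The measured steps alter only double-bond configuration, and all three compounds keep the group, so none gives a size for its loss. A higher number in this assay is expected, but only tentatively. The estimated step is a 6.8-fold higher number from compound 2 to compound 4 (0.83 log units; beyond the scatter). For compound 4 the expected value is 15 uM, within an estimated range of 4 uM to 60 uM.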

Compound 4, concentration for half-maximal effect: 1.3 uM
Beside the measured number, compound 4's estimate is 12-fold (1.06 log units) above it; measured number outside the range, below it.
By their numbers in this assay, from the lowest: compounds 4, 2, 3 and 1 (each within the scatter of the next, the first and the last beyond it).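

In this assay, replacing the group of 10 heavy atoms on this aromatic carbon with a hydrogen atom gives a 1.7-fold lower number from compound 2 to compound 4 (0.23 log units; within the scatter), so the loss of this whole group leaves no step beyond the scatter. The earlier compounds shown here kept the group and varied only double-bond configuration, whereas compound 4 shows that the assay number holds up with a single chain on the core. Nothing shown accounts for this outcome. Open, on these data alone, is whether an octyl chain, an amine or a carboxylic acid on this aromatic carbon would keep the number within the scatter of compound 4, and whether the remaining chain can also be replaced by a hydrogen atom.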